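The source may hold more compounds than are shown below. What is called first, only, known or untested is meant among the compounds shown, and "the series" means these compounds.

Measured in a functional assay on A549 cells (Homo sapiens) for cytotoxicity, read by MTT assay, with a stated time of 72 h; on this read-out higher numbers stand for weaker inhibition and lower numbers for stronger inhibition:
compound 1 `O=C(Nc1nc2ccccc2s1)c1cn(-c2ccccc2)nc1-c1ccccc1` gives 13500 nM
compound 2 `O=C(Nc1nc2ccccc2s1)c1cn(-c2ccccc2)nc1-c1ccc(F)cc1` gives 9010 nM
compound 3 `O=C(Nc1nc2ccccc2s1)c1cn(-c2ccccc2)nc1-c1ccc(Cl)cc1` gives 10300 nM

Compound 3 holds the second highest of these three numbers, but the step of a 1.3-fold lower number from compound 1 to compound 3 (0.12 log units; within the scatter) and the step of a 1.1-fold higher number from compound 2 to compound 3 (0.06 log units; within the scatter) both lie within the scatter, so the three compounds cannot be told apart. Compound 4 `COc1ccc2nc(NC(=O)c3cn(-c4ccccc4)nc3-c3ccc(Cl)cc3)sc2c1` differs from compound 3 by methoxy in place of hydrogen on an aromatic carbon. Within the data shown here, no measured step touches that fused ring; the steps of a 1.5-fold lower number from compound 1 to compound 2 (0.18 log units; within the scatter) and a 1.1-fold higher number from compound 2 to compound 3 (0.06 log units; within the scatter) concern a substituent on the separate phenyl ring and stayed within the scatter. The data therefore give no ground for expecting a shift beyond the scatter in this assay. Compound 4 is expected to give 9000 nM, with a range from 3000 nM to 30000 nM. The estimated step of a 1.1-fold lower number from compound 3 to compound 4 (0.06 log units; within the scatter) is a guess, not a measurement.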

Compound 4, half-maximal inhibitory concentration: 31400 nM
Compound 4: the middle estimate sits 3.5-fold (0.54 log units) below what was measured; the whole stated range lies below it.
By their numbers in this assay, from the lowest: compounds 2, 3 and 1 (each within the scatter of the next); then compound 4.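

In this assay, methoxy in place of hydrogen gives a 3.0-fold higher number from compound 3 to compound 4 (0.48 log units; beyond the scatter), a modest weakening of inhibition. Among these compounds, this is the only step so far that lies beyond the scatter, so this carbon of the fused ring system responds to a change, whereas fluoro and chloro on the separate phenyl ring did not shift the number beyond the scatter. Nothing measured here accounts for the shift.

On these data alone, it remains open whether a hydroxyl, an amine or a longer chain such as ethoxy at this position would also weaken inhibition, and whether methoxy would have the same effect on another carbon of this ring.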